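Methoxy to Methyl on Two Related Cores

The compounds below may be only part of what the source reports. "The series", "measured", "known", "first", "only" and "open" are said of these compounds alone.

Measured so far, in a functional assay on L1210 cells (Mus musculus) for cytotoxicity, with a stated time of 48 h; a higher number here means a weaker inhibitor, a lower number a stronger inhibitor:
compound 1, `COc1ccc(-c2nc3sc(Cc4ccc(Cl)cc4)nn3c2Br)cc1`: 63000 nM
compound 2, `Cc1ccc(-c2nc3sc(Cc4ccc(Cl)cc4)nn3c2Br)cc1`: > 250000 nM, a limit only
compound 3, `COc1ccc(-c2nc3sc(Cc4ccc(Cl)cc4)nn3c2C=O)cc1`: 5300 nM

Compound 2 reaches only a limit of this assay, not a number. The change from compound 1 to compound 2 is methyl in place of methoxy on an aromatic carbon, and it gives an at least 3.9-fold higher number from compound 1 to compound 2 (0.59 log units; beyond the scatter). That step is open-ended due to the limit of > 250000 nM in this assay, at which 1 of the 3 values shown sits. The cores of compound 1 and compound 3 differ by formyl in place of bromo on an aromatic carbon, which gives a 12-fold lower number from compound 1 to compound 3 (1.08 log units; beyond the scatter); compound 3 has the lowest number of the two measured in this assay.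

Compound 4, `Cc1ccc(-c2nc3sc(Cc4ccc(Cl)cc4)nn3c2C=O)cc1`, is not yet measured. It differs from compound 3 by methyl in place of methoxy on an aromatic carbon, the same change as from compound 1 to compound 2, made on the core of compound 3. Since that change gave an at least 3.9-fold higher number from compound 1 to compound 2 (0.59 log units; beyond the scatter), a step of at least that size is expected from compound 3 to compound 4, namely a 5.7-fold higher number from compound 3 to compound 4 (0.75 log units; beyond the scatter). Compound 4 is therefore estimated at 30000 nM in this assay, between 10000 nM and 150000 nM.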

Compound 4, half-maximal inhibitory concentration: 23000 nM
Compound 4: the middle estimate sits 1.3-fold (0.12 log units) above what was measured, within the range that was stated.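

In this assay, methyl in place of methoxy on the core of compound 3 gives a 4.3-fold higher number from compound 3 to compound 4 (0.64 log units; beyond the scatter), which runs in the same direction as the step on the core of compound 1: the same change on two cores in this assay, an at least 3.9-fold higher number (0.59 log units; beyond the scatter) from compound 1 to compound 2 and a 4.3-fold higher number (0.64 log units; beyond the scatter) from compound 3 to compound 4; the limit leaves it open whether they differ

Formyl in place of bromo likewise gives an at least 10-fold lower number from compound 2 to compound 4 (1.03 log units; beyond the scatter), in the same direction as on the methoxy pair: the same change on two cores in this assay, a 12-fold lower number (1.08 log units; beyond the scatter) from compound 1 to compound 3 and an at least 10-fold lower number (1.03 log units; beyond the scatter) from compound 2 to compound 4; the limit leaves it open whether they differ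

The value of compound 2, > 250000 nM, is a limit and not a number, so the four compounds show that both changes carry over in direction but do not show that either keeps its size, and two cores say nothing about a third: the limit of > 250000 nM in this assay, at which 1 of the 4 values shown sits.

The compounds shown leave open whether other groups in place of methoxy, such as an amine or a longer alkoxy chain, would follow the same direction on both cores. They also leave open how a carboxylic acid or a hydroxymethyl group in place of formyl would compare with the formyl compounds.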